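Shorter chain with bromine: compound 4 against compound 3

The source may report more compounds than this note shows. Statements on the series, on what has been measured and on what is new or still open speak of the compounds shown alone.

Compound 1 `O=C(CCc1ccccc1)Nc1nc2ccccc2c(=O)s1` is the reference point of this small series: in an assay on CHO cells for displacement of a labelled ligand from adenosine receptor A3 (Homo sapiens), read by scintillation counting, with a stated time of 60 min (on this read-out higher numbers stand for weaker inhibition and lower numbers for stronger inhibition), compound 1 gives 390 nM. Compound 2 `COc1cccc(CCC(=O)Nc2nc3ccccc3c(=O)s2)c1` carries a methoxy in place of hydrogen on an aromatic carbon, and in this assay compound 2 gives 173 nM, a change of a 2.3-fold lower number from compound 1 to compound 2 (0.35 log units; beyond the scatter). Compound 3 `O=C(CCCc1ccccc1)Nc1nc2ccccc2c(=O)s1` lengthens the chain by one carbon. For compound 3 only a limit of the assay is recorded, > 1000 nM, (the limit of > 1000 nM in this assay, at which 1 of the 3 values shown sits). Against the two numbered compounds this amounts to an at least 2.5-fold higher number from compound 1 to compound 3 (0.40 log units; beyond the scatter) and an at least 5.7-fold higher number from compound 2 to compound 3 (0.76 log units; beyond the scatter), so compound 3 stands at the weak end of what has been measured.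

Compound 4 `O=C(CCc1ccccc1Br)Nc1nc2ccccc2c(=O)s1` differs from compound 3 by 2-bromophenyl in place of benzyl on a saturated chain carbon, two bonds along the chain from a carbonyl carbon. Among the compounds with values here, this change largely reverses the step from compound 1 to compound 3, which was at least modest and toward weaker binding, while adding a bromine whose effect no measured pair shows. The step from compound 1 to compound 2 suggests that a substituent on that ring can shift the number modestly, in either direction here unknown. Compound 4 is therefore expected to come in near 400 nM, within a range of 150 nM to 1500 nM. That estimate corresponds to an expected step of an at least 2.5-fold lower number from compound 3 to compound 4 (0.39 log units; beyond the scatter).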

Compound 4, inhibition constant: > 1000 nM
Compound 4: only a limit was reported; the forecaster's own chance of this, stated with the estimate: 15%; at least 2.5-fold (0.39 log units) between middle value and limit.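

In this assay, bromo in place of hydrogen on an aromatic carbon gives an at least 2.5-fold higher number from compound 1 to compound 4 (0.40 log units; beyond the scatter), so a substituent on this ring can also move the number upward, whereas the earlier methoxy step went the other way. Exchanging one substituted ring for the other gives an at least 5.7-fold higher number from compound 2 to compound 4 (0.76 log units; beyond the scatter), so the two substituted rings fall on opposite sides of the unsubstituted one. The step between compound 3 and compound 4 cannot be read, since compound 4 reports only a limit of the assay, as compound 3 does: the limit of > 1000 nM in this assay, at which 2 of the 4 values shown sit.

Going by these compounds, how the shorter chain with bromine ranks against the longer chain without it therefore stays open, and so does any real size for the loss that bromine brings. Also open, on these data alone, is whether the drop belongs to bromine in particular or to any group at that place, which a fluoro group or a hydroxyl group on the ring of compound 1 would help to tell.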